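Demethylation at the Aryl Ketone of a Weak Cytotoxic Series

This account rests on a few compounds, and the source may have more. Where it says the series, first, only, none or still open, it means among the compounds named here.

Compound 2 `COc1ccc(C(=O)C2Sc3nnc(-c4cc(OC)c(OC)c(OC)c4)n3NC2c2ccco2)cc1` and compound 1 `COc1cc(-c2nnc3n2NC(c2ccco2)C(C(=O)C2CC2)S3)cc(OC)c1OC` share one core and differ only in the group on a carbonyl carbon. In a functional assay on PC-3 cells (Homo sapiens) for cytotoxicity, read by MTT assay, with a stated time of 48 h (on this read-out lower numbers stand for stronger inhibition and higher numbers for weaker inhibition), compound 1 gives 95200 nM. Compound 2 reaches only a limit of the assay, > 100000 nM, so no number is known for it. That limit is the limit of > 100000 nM in this assay, at which 1 of the 2 values shown sits. Among the measured compounds shown here, the only measured step, an at least 1.0-fold higher number from compound 1 to compound 2 (0.02 log units; that floor lies within the scatter), lies within the scatter and concerns a different position. Compound 3 `COc1cc(-c2nnc3n2NC(c2ccco2)C(C(=O)c2ccc(O)cc2)S3)cc(OC)c1OC` differs from compound 2 by hydrogen in place of methyl on an oxygen on an aromatic ring. For the measured compounds named here, no measured step touches this oxygen, so the expectation rests on compound 2 alone, whose value in this assay is a limit. The step is therefore expected to be a number no higher from compound 2 to compound 3 (the limit leaves the size open), with no direction beyond the scatter. Compound 3 is estimated at 100000 nM in this assay, ranging from 40000 nM to 250000 nM, and it may well again reach only a limit.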

Compound 3, half-maximal inhibitory concentration: 38300 nM
The estimate for compound 3 lay 2.6-fold (0.42 log units) above the measured number, outside the stated range (below it).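

In this assay, among the compounds shown here, hydrogen in place of methyl on the oxygen on the aromatic ring gives an at least 2.6-fold lower number from compound 2 to compound 3 (0.41 log units; beyond the scatter) and so provides the first reading at this oxygen, one that lies beyond the scatter. Compound 3 also separates from the cyclopropyl ketone, with a 2.5-fold lower number from compound 1 to compound 3 (0.40 log units; beyond the scatter) as the step, whereas the earlier step (an at least 1.0-fold higher number from compound 1 to compound 2 (0.02 log units; that floor lies within the scatter)) showed no change beyond the scatter. The methoxy to hydroxy step is only a floor, since compound 2 stands at a limit of the assay: the limit of > 100000 nM in this assay, at which 1 of the 3 values shown sits.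

On these data alone, whether this gain depends on the hydroxy group itself stays open, and an amine or a carboxylic acid on the aromatic ring in its stead would test that. The compounds shown also leave open how far the true value of compound 2 lies from that of compound 3.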